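Swapping Bromo for Methoxy on a Cytotoxic Scaffold

A few compounds are considered here, and "the series" means these few. Any claim that something is new, unique, unknown or untested is made for them only; others in the source may bear on it.

Measured so far in a functional assay on A549 cells (Homo sapiens) for cytotoxicity, read by MTT assay, with a stated time of 4 days; a higher number here means a weaker inhibitor, a lower number a stronger inhibitor:
Compound 1, `C=C1C(=O)[C@]23C[C@@]1(O)CC[C@H]2c1ccc(OS(=O)(=O)c2ccc(C)cc2)c(C)c1[C@@H]3Cn1cc(-c2ccc(Br)cc2)nn1`, gives 1630 nM.
Compound 2, `C=C1C[C@]23C[C@@]1(O)CC[C@H]2c1ccc(O)c(C)c1[C@@H]3Cn1cc(-c2ccc(C(F)(F)F)cc2)nn1`, gives 10400 nM.
Compound 3, `C=C1C(=O)[C@]23C[C@@]1(O)CC[C@H]2c1ccc(O)c(C)c1[C@@H]3Cn1cc(-c2ccc(Br)cc2)nn1`, gives 1140 nM.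

Among these three numbers, compound 1 stands second highest. Its nearest neighbour is compound 3, reached by a 1.4-fold lower number from compound 1 to compound 3 (0.16 log units; within the scatter), a change too small to count as a real difference. Compound 2, which differs from the others in more than one place, gives a clearly higher number than both compound 1 and compound 3.

The unmeasured compound 4, `C=C1C(=O)[C@]23C[C@@]1(O)CC[C@H]2c1ccc(OS(=O)(=O)c2ccc(C)cc2)c(C)c1[C@@H]3Cn1cc(-c2ccc(OC)cc2)nn1`, is built from compound 1 by one change: methoxy in place of bromo on an aromatic carbon. For the measured compounds named here, none of the measured steps touches this part of the molecule. Going by the values given here, the single one-place step available, from compound 1 to compound 3, concerns the oxygen on the other aromatic ring and lies within the scatter, so it gives no guide to what a change at this position does. With nothing comparable to lean on, the expectation for compound 4 is simply a number close to that of compound 1, with a wide band of uncertainty around it: the step from compound 1 to compound 4 is estimated as a 1.5-fold higher number from compound 1 to compound 4 (0.19 log units; within the scatter). For compound 4 the estimated value in this assay is therefore 2500 nM, expected to fall between 700 nM and 9000 nM.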

Compound 4, half-maximal inhibitory concentration: 1470 nM
For compound 4 the middle estimate is 1.7-fold (0.23 log units) above the measured one; measured number inside the range.
By their numbers in this assay, from the lowest: compounds 3, 4 and 1 (each within the scatter of the next); then compound 2.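

Set on the core of compound 1, the change from 4-bromophenyl to 4-methoxyphenyl gives, in this assay, a 1.1-fold lower number from compound 1 to compound 4 (0.04 log units; within the scatter), the first direct reading at this position. Bromo, with its single heavy atom and no hydrogen-bond acceptor, and methoxy, with two heavy atoms and one hydrogen-bond acceptor, cannot be told apart by this read-out in this pair, so these differences in what is counted leave no mark beyond the scatter here. Nothing available gives a measured reason for this result.

From the compounds shown here alone, this reading comes from a single pair, both members carrying the (4-methylphenyl)sulfonyl group on the oxygen, so it remains open whether methoxy and bromo would also read alike on the free hydroxyl form seen in compound 3. Going by these compounds, it is also open whether this tolerance extends to quite different groups at the same place on the ring, such as an amine, a carboxylic acid or a longer chain, since one swap cannot show how far it reaches.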